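From methoxymethyl to ethoxymethyl on a shared core

The source may report more compounds than this note shows. Statements on the series, on what has been measured and on what is new or still open speak of the compounds shown alone.

Measured so far in a functional assay on A-431 cells (Homo sapiens) for inhibition, with a stated time of 72 h (on this read-out lower numbers stand for stronger inhibition and higher numbers for weaker inhibition), for three compounds
- compound 1 `CCOCc1cc(CN2CCCC2)c(O)c2ncccc12` gives 33100 nM
- compound 2 `CC1CCN(Cc2cc(Cl)c3cccnc3c2O)CC1` gives 8710 nM
- compound 3 `COCc1cc(CN2CCC(C)CC2)c(O)c2ncccc12` gives 13800 nM

Compound 3 sits in the middle of these three numbers. Its value lies within the scatter of compound 2, while compound 1 gives a higher number beyond the scatter. The next compound is compound 4 `CCOCc1cc(CN2CCC(C)CC2)c(O)c2ncccc12` and the change is methyl in place of hydrogen on a saturated chain carbon bound to an oxygen on a saturated carbon with methyl in place of hydrogen on a saturated chain carbon bound to an oxygen on a saturated carbon, so methoxy becomes ethoxy. For the measured compounds named here, only one measured step touches this group: a 1.6-fold higher number from compound 2 to compound 3 (0.20 log units; within the scatter) where methoxymethyl replaces chloro. Going by the values given here, compound 1 also carries ethoxymethyl, but it differs from compound 4 elsewhere too, so no measured step isolates this change. No step beyond the scatter is expected in this assay on this evidence. The expected step is a 1.0-fold higher number from compound 3 to compound 4 (0.01 log units; within the scatter) and it is small. For compound 4 the estimated value is 14000 nM with an expected range of 7000 nM to 28000 nM around it.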

Compound 4, half-maximal inhibitory concentration: 11000 nM
The estimate for compound 4 lay 1.3-fold (0.10 log units) above the measured number; low and high end bracket the measured number.
By their numbers in this assay, from the lowest: compounds 2, 4 and 3 (each within the scatter of the next); then compound 1.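

In this assay, the added methyl that turns methoxymethyl into ethoxymethyl stays within the scatter (a 1.3-fold lower number from compound 3 to compound 4 (0.10 log units; within the scatter)), and so does ethoxymethyl in place of chloro (a 1.3-fold higher number from compound 2 to compound 4 (0.10 log units; within the scatter)), so this position tolerated all three of these groups on the shared core with 4-methylpiperidin-1-yl. For the compounds shown here, with ethoxymethyl held constant, 4-methylpiperidin-1-yl in place of pyrrolidin-1-yl gives the only new step beyond the scatter, a modest one (a 3.0-fold lower number from compound 1 to compound 4 (0.48 log units; beyond the scatter)), which places the clearest difference at the saturated chain carbon bound to an aromatic carbon rather than at the ether chain. No independent measurement bears on why these numbers fall as they do.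

As far as these compounds go, whether a longer chain such as propoxymethyl, or an amine or a carboxylic acid, would also stay within the scatter at this position remains open. So does whether the methoxymethyl and ethoxymethyl groups would match each other on a core carrying pyrrolidin-1-yl.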